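The source may hold more compounds than are shown below. What is called first, only, known or untested is meant among the compounds shown, and "the series" means these compounds.

Series on the shared core of compound 1 `CC(C)=CCC1Cc2c(OCc3ccccc3)cc(=O)n(CCCO)c2CC1(C)C`, compound 2 `CC(C)=CCC/C(C)=C/COc1cc(=O)n(CCCO)c2c1CC(CC=C(C)C)C(C)(C)C2` and compound 3 `CC(C)=CCC1Cc2c(OCCCOc3ccc(Cl)cc3)cc(=O)n(CCCO)c2CC1(C)C`, varied in the group on the oxygen on the aromatic ring. In a functional assay on PANC-1 cells (Homo sapiens) for inhibition, read by MTT assay, with a stated time of 24 h, tested at 10 uM (on this read-out higher numbers stand for more inhibition at the one concentration tested (going by the name of the read-out) and lower numbers for less inhibition), compound 1 gives -0.3%, compound 2 gives 10.6% and compound 3 gives 22.7%, the highest of the three, clear of both others. The steps of a number 23 percentage points higher from compound 1 to compound 3 (beyond the scatter) and a number 12.1 percentage points higher from compound 2 to compound 3 (beyond the scatter) show that exchanging the group on this oxygen moves the read-out by modest amounts. Compound 4 `CC(C)=CCC1Cc2c(OC(=O)Nc3ccc(F)cc3)cc(=O)n(CCCO)c2CC1(C)C` carries (4-fluorophenyl)carbamoyl in place of 3-(4-chlorophenoxy)propyl on an oxygen on an aromatic ring. Within the data shown here, no measured step covers a carbamoyl group on this oxygen, so only the scale of the earlier exchanges guides the expectation. A modest fall, a number 10.7 percentage points lower from compound 3 to compound 4 (beyond the scatter), is expected in this assay. Compound 4 is estimated at 12%, within -5% to 30%.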

Compound 4, a percentage reported as inhibition, at one concentration (the size of the read-out at that concentration, not a potency): 71.2%
Compound 4: middle estimate off by 59.2 percentage points, on the low side; measured number above the stated range.
By their numbers in this assay, from the lowest: compound 1; then compound 2; then compound 3; then compound 4.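

On the oxygen on an aromatic ring, (4-fluorophenyl)carbamoyl gives by far the largest steps in this series in this assay: a number 48.5 percentage points higher from compound 3 to compound 4 (beyond the scatter), a number 60.6 percentage points higher from compound 2 to compound 4 (beyond the scatter) and a number 71.5 percentage points higher from compound 1 to compound 4 (beyond the scatter). The modest spread among benzyl, 3,7-dimethylocta-2,6-dien-1-yl and 3-(4-chlorophenoxy)propyl therefore did not mark the limit of this position. Nothing available explains why this change has such an effect. As far as these compounds go, whether the carbamoyl link or the 4-fluorophenyl ring carries the gain remains open. Phenylcarbamoyl and methylcarbamoyl groups on this oxygen would help separate the two.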